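Swapping a Pyridyl Amide for a Cyclohexenyl Amide

This account rests on a few compounds, and the source may have more. Where it says the series, first, only, none or still open, it means among the compounds named here.

Two compounds share one core and differ only in the group on the carbonyl carbon of an amide. Compound 1 `O=C(Nc1cc(-c2ccccc2)nn1-c1ccccc1)c1ccc(C(F)(F)F)cc1` carries 4-(trifluoromethyl)phenyl there, and in a functional assay on cells for positive allosteric modulation of metabotropic glutamate receptor 5 (Rattus norvegicus), read by calcium flux (a higher number here means that more compound is needed for the effect, a lower number that less compound is needed), compound 1 gives 38 nM. Compound 2 `Cc1ccc(C(=O)Nc2cc(-c3ccccc3)nn2-c2ccccc2)cn1` carries 6-methylpyridin-3-yl instead; in this assay compound 2 gives 280 nM, the higher of the two numbers, and the step of a 7.4-fold higher number from compound 1 to compound 2 (0.87 log units; beyond the scatter) lies beyond the scatter. Compound 3 `O=C(Nc1cc(-c2ccccc2)nn1-c1ccccc1)C1=CCCCC1` is not yet measured; it differs from compound 2 by cyclohex-1-en-1-yl in place of 6-methylpyridin-3-yl on a carbonyl carbon. Among the measured compounds shown here, the one measured step shows only that exchanging one aromatic ring for another at this carbonyl carbon shifted the number modestly; no measured step involves a non-aromatic ring, so the direction here is open. The number for compound 3 is therefore expected to stay near that of compound 2, a step of a 1.4-fold higher number from compound 2 to compound 3 (0.15 log units; within the scatter). Compound 3 is estimated at 400 nM, with a range from 100 nM to 2000 nM.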

Compound 3, half-maximal effective concentration: 3300 nM
Compound 3: middle estimate off by 8.3-fold (0.92 log units), on the low side; measured number outside the range, above it.
By their numbers in this assay, from the lowest: compound 1; then compound 2; then compound 3.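

Among the compounds shown here, this is the first measured step to a non-aromatic ring on this carbonyl carbon, and cyclohex-1-en-1-yl in place of 6-methylpyridin-3-yl gives a 12-fold higher number from compound 2 to compound 3 (1.07 log units; beyond the scatter) in this assay. Set against 4-(trifluoromethyl)phenyl, the same ring gives an 87-fold higher number from compound 1 to compound 3 (1.94 log units; beyond the scatter), so among these three compounds both groups with an aromatic ring need less compound for the effect than the single non-aromatic one. Nothing measured here explains this difference.

Both aromatic groups carry a substituent on the ring and cyclohex-1-en-1-yl carries none, so these compounds cannot separate the change of ring type from the loss of that substituent. Unsubstituted phenyl, saturated cyclohexyl or an open pentyl chain on the same carbonyl carbon would each test a different part of this question.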